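The source may report more compounds than this note shows. Statements on the series, on what has been measured and on what is new or still open speak of the compounds shown alone.

Compounds built on one shared core differ here only in the group on a saturated chain carbon bound to a carbonyl carbon, and they are compared in a functional assay on HCT-8 cells (Homo sapiens) for antiproliferative activity, read by MTT assay, with a stated time of 48 h; on this read-out higher numbers stand for weaker inhibition and lower numbers for stronger inhibition. With methoxy at that place, compound 1 (`C=C(c1cc(OC)c(OC)c(OC)c1)c1ccc(OC)c(O)c1NC(=O)COC`) gives (280 nM). With ethoxy, compound 2 (`C=C(c1cc(OC)c(OC)c(OC)c1)c1ccc(OC)c(O)c1NC(=O)COCC`) gives (910 nM). With dimethylamino, compound 3 (`C=C(c1cc(OC)c(OC)c(OC)c1)c1ccc(OC)c(O)c1NC(=O)CN(C)C`) gives (110 nM), the lowest number of the three.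

Compound 4 (`C=C(c1cc(OC)c(OC)c(OC)c1)c1ccc(OC)c(O)c1NC(=O)CO`) carries hydroxy in place of dimethylamino at that carbon (hydroxy in place of dimethylamino on a saturated chain carbon bound to a carbonyl carbon). Within the data shown here, no measured compound has hydroxy there, so the evidence is indirect. Both oxygen-linked groups gave higher numbers than dimethylamino, as the steps show (a 2.5-fold lower number from compound 1 to compound 3 (0.41 log units; beyond the scatter); an 8.3-fold lower number from compound 2 to compound 3 (0.92 log units; beyond the scatter)). Extending methoxy to ethoxy also raised the number (a 3.3-fold higher number from compound 1 to compound 2 (0.51 log units; beyond the scatter)), so compound 1 is the closer guide.

A modest rise is therefore expected in this assay (a 2.3-fold higher number from compound 3 to compound 4 (0.36 log units; beyond the scatter)), although it may not clear the usual scatter. The estimate for compound 4 is (250 nM), with an expected range from (80 nM) to (800 nM).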

Compound 4, half-maximal inhibitory concentration: 40 nM
Beside the measured number, compound 4's estimate is 6.3-fold (0.80 log units) above it, outside the stated range (below it).
By their numbers in this assay, from the lowest: compound 4; then compound 3; then compound 1; then compound 2.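

Removing the alkyl group from the oxygen lowers the number in this assay, both from methoxy (a 7.0-fold lower number from compound 1 to compound 4 (0.85 log units; beyond the scatter)) and, by a large step, from ethoxy (a 23-fold lower number from compound 2 to compound 4 (1.36 log units; beyond the scatter)), so the number rises along hydroxy, methoxy and ethoxy in these compounds. Hydroxy also beats dimethylamino (a 2.8-fold lower number from compound 3 to compound 4 (0.44 log units; beyond the scatter)), which shows that an oxygen-linked group at this carbon need not give a higher number than dimethylamino, and makes compound 4 the most potent of the four. Nothing measured here bears on why these steps occur.

Going by these compounds, it remains open whether a plain amino group or a methylamino group at this carbon would give numbers closer to hydroxy or to dimethylamino. Whether a carboxylic acid or a longer hydroxyalkyl chain would keep the low number of compound 4 is also unresolved.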